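The source may report more compounds than this note shows. Statements on the series, on what has been measured and on what is new or still open speak of the compounds shown alone.

Of the compounds shown here, three sharing one core have been measured in an assay on cells with melanin-concentrating hormone receptor 1 (Homo sapiens) as the target, read by radioligand binding; a lower number here means a stronger inhibitor, a higher number a weaker inhibitor. Compound 1 `Nc1ccc2cccc(OC3CCCCC3)c2n1` carries cyclohexyl on an oxygen on an aromatic ring, and in this assay compound 1 gives 361 nM. Compound 2 `CCOCCOc1cccc2ccc(N)nc12` carries 2-ethoxyethyl in that place, and for compound 2 this assay reports only a limit, > 2000 nM. Compound 3 `Nc1ccc2cccc(OC3CCCC3)c2n1` carries cyclopentyl there, and for compound 3 this assay likewise reports only a limit, > 2000 nM. The two readable steps are an at least 5.5-fold higher number from compound 1 to compound 2 (0.74 log units; beyond the scatter) and an at least 5.5-fold higher number from compound 1 to compound 3 (0.74 log units; beyond the scatter), while the step between compound 2 and compound 3 cannot be sized because of the limit of > 2000 nM in this assay, at which 2 of the 3 values shown sit.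

Compound 3 therefore stands at the limit; only compound 1 gives a number, and compound 3 is at least modestly weaker than compound 1.

Compound 4 `Nc1ccc2cccc(OCC3CCC3)c2n1` has not yet been measured. It differs from compound 3 in one place: cyclobutylmethyl in place of cyclopentyl on an oxygen on an aromatic ring. Among the measured compounds shown here, no measured step moves atoms between a ring and a side chain in this way, so the only guide is that the change from compound 1 to compound 3, an at least 5.5-fold higher number from compound 1 to compound 3 (0.74 log units; beyond the scatter), already carried the value to the limit. From there the expected step is a step that the limit leaves unreadable from compound 3 to compound 4, meaning another weak result is expected. For compound 4 the estimate in this assay is 2500 nM, between 700 nM and 9000 nM.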

Compound 4, half-maximal inhibitory concentration: 432 nM
Compound 4: middle estimate off by 5.8-fold (0.76 log units), on the high side; measured number outside the range, below it.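

Cyclopentyl and cyclobutylmethyl contain the same atoms, joined differently, yet in this assay replacing the first with the second gives an at least 4.6-fold lower number from compound 3 to compound 4 (0.66 log units; beyond the scatter), so on this oxygen the arrangement of the carbons matters, not only their number. The ring also need not be cyclohexyl joined directly to the oxygen, since replacing cyclohexyl with cyclobutylmethyl gives a 1.2-fold higher number from compound 1 to compound 4 (0.08 log units; within the scatter), and these two compounds cannot be told apart in this assay. Cyclobutyl in place of ethoxymethyl on the saturated chain carbon bound to the oxygen gives an at least 4.6-fold lower number from compound 2 to compound 4 (0.66 log units; beyond the scatter), and this step and the one from compound 3 are minimum sizes only because compound 2 and compound 3 each sit at a limit rather than a true number: the limit of > 2000 nM in this assay, at which 2 of the 4 values shown sit.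

As far as these compounds go, whether a ring is needed at all remains open, as an open carbon chain such as pentyl would test that directly. Also unresolved is whether a larger group, such as cycloheptyl or cyclohexylmethyl, would lower the number further, or whether a ring holding nitrogen, such as piperidine, could take the place of these carbon rings.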